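The compounds below may be only part of what the source reports. "The series", "measured", "known", "first", "only" and "open" are said of these compounds alone.

Measured compounds:
- compound 1, `CCCCc1cnc(C(CCC)Cc2ccc(-c3ccccc3C(=O)O)cc2)[nH]1`, in an in vitro functional assay on cells for agonist activity at Bombesin receptor subtype-3 (Mus musculus), read by luminescence and calcium flux (on this read-out lower numbers stand for an effect already at smaller amounts and higher numbers for an effect only at larger amounts of compound), compound 1 gives 165 nM
- compound 2, `Cc1cccc(Cc2cnc(CCc3ccc(-c4ccccc4C(=O)O)cc3)[nH]2)c1`, in this assay compound 2 gives 75 nM

Compound 2 stands at the lowest of the two numbers shown. Compound 1 gives the higher number, and the gap between the two values lies beyond the usual scatter, so compound 2 shows its effect at the smaller amount of the pair. Among the measured compounds shown here, no single-point step between these two measured compounds is given, so only their two values can be compared.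

Compound 3, `O=C(O)c1ccccc1-c1ccc(CCc2ncc(CC3CC3)[nH]2)cc1`, has not yet been measured in this assay. It differs from compound 2 in one place: cyclopropyl in place of 3-methylphenyl on a saturated chain carbon bound to an aromatic carbon. The larger six-membered aromatic ring of compound 2 is thus replaced by a small three-membered ring, while the shared core and the rest of the chain stay the same.

For the measured compounds named here, with only two measured compounds, the expectation rests on the values of compound 1 and compound 2. Compound 2 carries the larger group and gives the lower number; the smaller groups present here sit at the higher end. The step from compound 2 to compound 3 is therefore expected to read a 4.7-fold higher number from compound 2 to compound 3 (0.67 log units; beyond the scatter), toward a higher number and beyond the scatter. For compound 3 the estimated value in this assay is 350 nM, within a range from 100 nM to 1200 nM.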

Compound 3, half-maximal effective concentration: 72 nM
Compound 3: middle estimate off by 4.9-fold (0.69 log units), on the high side; the whole stated range lies above it.
By their numbers in this assay, from the lowest: compounds 3 and 2 (each within the scatter of the next); then compound 1.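

In this assay, putting cyclopropyl in place of 3-methylphenyl on a saturated chain carbon bound to an aromatic carbon gives a 1.0-fold lower number from compound 2 to compound 3 (0.02 log units; within the scatter), so this read-out does not separate the two groups at this position. Compound 1 and compound 2 differ in more than one place, and their gap could not be assigned to any single group; this pair isolates one change and shows that a six-membered aromatic ring of carbon only is not required here, as a three-membered non-aromatic ring of carbon only, with 3 heavy atoms instead of 7, reads at the same level. Nothing available here explains why these two groups read alike.

From the compounds shown here alone, it remains open whether this tolerance extends to an open-chain group such as hexyl, to a plain methyl, or to a group carrying an amine or a hydroxyl at the same place. Going by these compounds, it is also open whether a cyclohexyl or a pyridyl ring would read at this level, and whether the two groups would still match if a tetrazole replaced the carboxylic acid elsewhere on the shared core.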